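A few compounds are considered here, and "the series" means these few. Any claim that something is new, unique, unknown or untested is made for them only; others in the source may bear on it.

Working notes on the series. Every compound here carries the shared core of compound 1 `O=C(C1CCC(F)(F)CC1)N1CC(c2nc(-c3cccc(F)c3)no2)C1` and differs only in the group attached at the acyl end of that core. In an assay on HEK293 cells for negative allosteric modulation of metabotropic glutamate receptor 5 (Homo sapiens), read by FLIPR (a lower number here means a stronger inhibitor, a higher number a weaker inhibitor), compound 1 gives only a limit, > 10000 nM. Compound 2 `Cc1cccc(-c2noc(C3CN(S(=O)(=O)c4cccc(C)c4)C3)n2)c1` gives 650 nM in this assay. Compound 3 `CC1CCCC(C(=O)N2CC(c3nc(-c4cccc(Cl)c4)no3)C2)C1` likewise gives only a limit in this assay, > 10000 nM. Where compound 3 stands is therefore fixed only by the limit of > 10000 nM in this assay, at which 2 of the 3 values shown sit; between compound 2 and compound 3 no step is measured, and the two values show just that compound 2 returns a number while compound 3 does not. Compound 4 `O=C(N1CCC(F)CC1)N1CC(c2nc(-c3cccc(Cl)c3)no2)C1` differs from compound 3 by 4-fluoropiperidin-1-yl in place of 3-methylcyclohexyl on a carbonyl carbon. Going by the values given here, no single-point step between measured compounds exists in this set, so the size of such a change cannot be read from the data. The expected step from compound 3 to compound 4 is an at least 1.1-fold lower number from compound 3 to compound 4 (0.04 log units; that floor lies within the scatter), which is to say no shift beyond the scatter in either direction is expected. Compound 4 is estimated at 9000 nM in this assay, with a range from 2500 nM to 30000 nM.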

Compound 4, half-maximal inhibitory concentration: > 10000 nM
Compound 4 ended at the assay's limit; the forecaster's own chance of this, stated with the estimate: 55%; middle value at least 1.1-fold (0.04 log units) away from the limit.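

Compound 3 and compound 4 both give only a limit in this assay, so no step between them can be read, and compound 4 sits with the others at that limit: the limit of > 10000 nM in this assay, at which 3 of the 4 values shown sit.

The compounds shown leave open whether 4-fluoropiperidin-1-yl in place of 3-methylcyclohexyl on a carbonyl carbon shifts the number at all, and which single change separates compound 2 from the compounds at the limit.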